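A Fluorophenyl Ester Judged Against Three Measured Analogues

The source may report more compounds than this note shows. Statements on the series, on what has been measured and on what is new or still open speak of the compounds shown alone.

Three aryl sulfonate esters built on one shared core have been tested in a functional assay on M21 cells (Homo sapiens) for antiproliferative activity, read by sulforhodamine B assay, with a stated time of 48 h; on this read-out higher numbers stand for weaker inhibition and lower numbers for stronger inhibition. Compound 1 `Cc1ccc(OS(=O)(=O)c2ccc(N3CCN(C)C3=O)cc2)c(C)c1` gives 1800 nM. Compound 2 `COc1ccc(OS(=O)(=O)c2ccc(N3CCN(C)C3=O)cc2)cc1OC` gives 8500 nM, and compound 3 `COc1cc(OS(=O)(=O)c2ccc(N3CCN(C)C3=O)cc2)cc(OC)c1OC` gives 54 nM. Compound 1 therefore stands second highest of the three, nearer to compound 2 than to compound 3. Going by the values given here, the only single-point step among them is a 160-fold lower number from compound 2 to compound 3 (2.20 log units; beyond the scatter), a methoxy in place of hydrogen on an aromatic carbon. Compound 4 `CN1CCN(c2ccc(S(=O)(=O)Oc3ccc(F)cc3)cc2)C1=O` differs from compound 1 by 4-fluorophenyl in place of 2,4-dimethylphenyl on an oxygen. Among the compounds with values here, no measured step swaps the whole aryl group on that oxygen, so this change has no direct precedent, though the spread across compounds 1, 2 and 3 shows the group matters greatly. Compound 4 is expected near 4000 nM (range 1000 nM to 20000 nM), a step of a 2.2-fold higher number from compound 1 to compound 4 (0.35 log units; beyond the scatter) that may fall within the scatter.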

Compound 4, half-maximal inhibitory concentration: > 100000 nM
Compound 4 was reported as a limit; the forecaster's own chance of this, stated with the estimate: 15%; middle value at least 25-fold (1.39 log units) from the limit.
By their numbers in this assay, from the lowest: compound 3; then compound 1; then compound 2. At a limit, above all of these: compound 4.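

Compound 4 gives > 100000 nM in this assay, which is a limit of the assay and not a number. Its step, an at least 55-fold higher number from compound 1 to compound 4 (1.74 log units; beyond the scatter), shows that 4-fluorophenyl in place of 2,4-dimethylphenyl on this oxygen can carry the read-out past the measurable range, whereas the earlier aryl groups all gave numbers. The true size of the step cannot be read past that limit: the limit of > 100000 nM in this assay, at which 1 of the 4 values shown sits.

The compounds shown leave open whether the step follows from the entering fluorine or from the loss of the methyl groups. A plain phenyl or a 4-methoxyphenyl group on the same oxygen would help separate the two.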